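Swapping dimethylamino for methoxyethoxy on a shared core

The source may report more compounds than this note shows. Statements on the series, on what has been measured and on what is new or still open speak of the compounds shown alone.

Measured so far:
compound 1 `CCCCCOc1nc(N)nc2c1ncn2/C=C1/CC1(CO)CO` — > 20000 nM (a limit)
compound 2 `CCCCCCSc1nc(N)nc2c1ncn2/C=C1/CC1(CO)CO` — > 20000 nM (a limit)
compound 3 `CN(C)c1nc(N)nc2c1ncn2/C=C1/CC1(CO)CO` — "not determined" (no result reported)

In an ADME assay on MOLT-3 cells (Homo sapiens) for cytotoxicity, with a stated time of 7 days (on this read-out higher numbers stand for lower toxicity in this test and lower numbers for higher toxicity in this test), compound 1 gives > 20000 nM, which is a limit of the assay and not a number. Compound 2 likewise gives > 20000 nM, again a limit. Compound 3 has no result, its entry reading "not determined" (no result reported), so compound 3 stands without a single number. The two other values shown are limits. Among the measured compounds shown here, the one measured step, a step that the two limits leave unreadable from compound 1 to compound 2, is hexylsulfanyl in place of pentyloxy on an aromatic carbon; the limit of > 20000 nM in this assay, at which 2 of the 3 values shown sit, is where two of the three values sit, so its size cannot be read. Compound 4 `COCCOc1nc(N)nc2c1ncn2/C=C1/CC1(CO)CO` differs from compound 3 by 2-methoxyethoxy in place of dimethylamino on an aromatic carbon. For the measured compounds named here, no measured step bears on this change, and no size or direction can be expected beyond the scatter. Compound 4 is therefore estimated at 30000 nM in this assay, within 10000 nM to 100000 nM, most likely reported as another limit.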

Compound 4, half-maximal cytotoxic concentration: > 20000 nM
Compound 4: only a limit was reported; the forecaster's own chance of this, stated with the estimate: 75%; the middle value is on the limit's open side.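

No step can be read between compound 1, compound 2 and compound 4, since each value is a limit and not a number: the limit of > 20000 nM in this assay, at which 3 of the 4 values shown sit.

Going by these compounds, how toxic these compounds are in this assay stays open, as does where compound 3 stands.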